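A few compounds are considered here, and "the series" means these few. Any claim that something is new, unique, unknown or untested is made for them only; others in the source may bear on it.

In a functional assay on VCaP cells (Homo sapiens) for antiproliferative activity, read by propidium iodide staining, with a stated time of 96 h (on this read-out higher numbers stand for weaker inhibition and lower numbers for stronger inhibition), compound 1 `CC(O)(CSc1cccc(C(F)(F)F)c1)C(=O)Nc1cccc(S(F)(F)(F)(F)F)c1` gives 20200 nM as its reading. Compound 2 `CC(O)(CSc1cc(C(F)(F)F)cc(C(F)(F)F)c1)C(=O)Nc1cccc(S(F)(F)(F)(F)F)c1` gives 4000 nM in the same assay, and the change trifluoromethyl in place of hydrogen on an aromatic carbon made a step of a 5.1-fold lower number from compound 1 to compound 2 (0.70 log units; beyond the scatter) between them. Compound 3 `CC(O)(COc1ccc(C#N)cc1)C(=O)Nc1cccc(S(F)(F)(F)(F)F)c1` gives 26600 nM in this assay, and how its core differs from the core of compound 1 is not broken down here. Compound 4 `CC(O)(COc1ccc(C#N)cc1C(F)(F)F)C(=O)Nc1cccc(S(F)(F)(F)(F)F)c1` has not yet been measured in this assay. It carries the change trifluoromethyl in place of hydrogen on an aromatic carbon relative to compound 3, which is the same kind of change as the earlier one, not the same: here the place is ortho to a large group and meta to a cyano group, whereas before it was meta to a large group and meta to a trifluoromethyl group. A somewhat smaller step is expected, namely a 3.0-fold lower number from compound 3 to compound 4 (0.47 log units; beyond the scatter) as an estimate, resting on a 5.1-fold lower number from compound 1 to compound 2 (0.70 log units; beyond the scatter) and on the differing surroundings of the place. Compound 4 is therefore expected to give about 9000 nM in this assay. The estimated range runs from 3000 nM to 27000 nM for compound 4 in this assay.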

Compound 4, half-maximal inhibitory concentration: 30600 nM
Compound 4: the middle estimate sits 3.4-fold (0.53 log units) below what was measured; the measured number lies above the stated range.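

On the core of compound 3, trifluoromethyl in place of hydrogen gave a 1.2-fold higher number from compound 3 to compound 4 (0.06 log units; within the scatter) in this assay, so the lower number seen on the core of compound 1 did not carry over. The same change therefore behaved differently on the two cores: the same change on two cores in this assay, a 5.1-fold lower number (0.70 log units; beyond the scatter) from compound 1 to compound 2 and a 1.2-fold higher number (0.06 log units; within the scatter) from compound 3 to compound 4, 5.8-fold (0.76 log units) apart, beyond the scatter of two such steps. Going by these compounds alone, with only one pair per core, and with cores and surroundings that differ in more than one place, these data do not show which difference matters, and they do not show how the change would behave on any other core.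

From the compounds shown here alone, it remains open how a methoxy group or an amine at this same place would read in this assay. Going by these compounds, it is also open whether trifluoromethyl elsewhere on this aromatic ring would lower the number.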